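Carboxyphenyl position on the shared core: compound 3 to compound 4

The source may hold more compounds than are shown below. What is called first, only, known or untested is meant among the compounds shown, and "the series" means these compounds.

Three members of the series have numbers in an assay on isolated protein for agonist activity at Bile acid receptor (Homo sapiens), read by FRET; a lower number here means a smaller maximal response, a higher number a larger maximal response. Compound 1 `CN(Cc1ccc(C(=O)O)cc1)c1ccc(OCc2c(-c3c(Cl)cccc3Cl)noc2C2CC2)nc1C(F)(F)F` gives 109%, compound 2 `CC(Nc1ccc(C(=O)O)cc1)c1ccc(OCc2c(-c3c(Cl)cccc3Cl)noc2C2CC2)nc1C(F)(F)F` gives 99%, and compound 3 `O=C(O)c1cccc(OCc2ccc(OCc3c(-c4c(Cl)cccc4Cl)noc3C3CC3)nc2C(F)(F)F)c1` gives 98%. Compound 3 has the lowest of the three numbers; its nearest neighbour is compound 2, the gap being a number 1 percentage points lower from compound 2 to compound 3 (within the scatter), while the larger gap is a number 11 percentage points lower from compound 1 to compound 3 (beyond the scatter), a modest step. The step of a number 10 percentage points lower from compound 1 to compound 2 (within the scatter) lies within the scatter.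

Compound 4 `O=C(O)c1ccc(OCc2ccc(OCc3c(-c4c(Cl)cccc4Cl)noc3C3CC3)nc2C(F)(F)F)cc1` differs from compound 3 in one place: 4-carboxyphenyl in place of 3-carboxyphenyl on an oxygen on a saturated carbon. Among the measured compounds shown here, no measured step isolates this change. Compounds 1 and 2 carry a 4-carboxy group on their aromatic ring with other linkers, and compound 3 carries a 3-carboxyphenoxy group; the moves a number 11 percentage points lower from compound 1 to compound 3 (beyond the scatter) and a number 1 percentage points lower from compound 2 to compound 3 (within the scatter) mix the carboxy position with the linker, so they bear on the change only loosely. All three numbers sit close to the control level, so a step of at most modest size, without a clear direction, is expected in this assay.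

For compound 4 the expected value in this assay is 102%, within 88% to 115%. This corresponds to an expected step of a number 4 percentage points higher from compound 3 to compound 4 (within the scatter), judged within the scatter.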

Compound 4, largest response reached (reported as efficacy), in percent of the reference or control that the assay uses: 86%
Beside the measured number, compound 4's estimate is 16 percentage points above it; the measured number lies below the stated range.
By their numbers in this assay, from the lowest: compound 4; then compounds 3, 2 and 1 (each within the scatter of the next, the first and the last beyond it).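

In this assay, the swap of 3-carboxyphenyl for 4-carboxyphenyl on an oxygen on a saturated carbon can now be read on its own, with everything else held constant: the step is a number 12 percentage points lower from compound 3 to compound 4 (beyond the scatter), so the placement of the carboxy group on this ring changes the maximal response. The (4-carboxyphenoxy)methyl group also stands apart from the two other linkers, at a number 13 percentage points lower from compound 2 to compound 4 (beyond the scatter) and a number 23 percentage points lower from compound 1 to compound 4 (beyond the scatter), which shows that a 4-carboxy group does not by itself give the larger responses of compound 1 and compound 2; the linker that carries it counts as well. No measurement shown here accounts for the drop in response with the 4-carboxyphenyl group.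

Still open, on these data alone, is whether 2-carboxyphenyl on the same oxygen would continue this trend, and whether a tetrazole or a primary carboxamide in place of the carboxylic acid would keep the response of compound 3. Also open, as far as these compounds go, is whether 3-carboxyphenyl attached through the amine linkers of compound 1 and compound 2 would shift the response in the same direction, since only maximal response is available and potency remains unknown.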